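Phenyl to benzyl, from a limit

The source may report more compounds than this note shows. Statements on the series, on what has been measured and on what is new or still open speak of the compounds shown alone.

Compound 1 `Cc1noc(CC2OC(=O)c3ccccc32)n1`: > 40000 nM
Compound 2 `O=C1OC(Cc2nc(-c3ccccc3)no2)c2ccccc21`: > 40000 nM

Both results come from an ADME assay on RAW264.7 cells (Mus musculus) for cytotoxicity, read by MTT assay, with a stated time of 24 h, in the presence of a further agent that is not named here (a lower number here means a stronger inhibitor, a higher number a weaker inhibitor), and each is a limit of the assay rather than a number. Compound 2 stands with compound 1 at the limit of > 40000 nM in this assay, at which 2 of the 2 values shown sit. Within the data shown here, the only measured change, phenyl in place of methyl on an aromatic carbon, is a step that the two limits leave unreadable from compound 1 to compound 2. It therefore gives no size to carry forward.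

Compound 3 `O=C1OC(Cc2nc(Cc3ccccc3)no2)c2ccccc21` differs from compound 2 by one change: benzyl in place of phenyl on an aromatic carbon.

With no readable step to draw on, no shift beyond the scatter is expected in this assay, in either direction, and the assay will most likely report another limit. The expected step is a number no higher from compound 2 to compound 3 (the limit leaves the size open). Compound 3 is estimated at 40000 nM, with an expected range from 20000 nM to 80000 nM.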

Compound 3, half-maximal inhibitory concentration: > 40000 nM
Compound 3 ended at the assay's limit (the forecaster's own chance of this, stated with the estimate: 85%); the middle value lies on the limit itself.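

The steps from compound 1 and from compound 2 to compound 3 cannot be read in this assay, as each compound gives a limit of the assay rather than a number: the limit of > 40000 nM in this assay, at which 3 of the 3 values shown sit.

The compounds shown leave open whether methyl, phenyl and benzyl on the shared core differ at all in this assay.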